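Octyl chain in place of azidohexyl on the carbamate core

A few compounds are considered here, and "the series" means these few. Any claim that something is new, unique, unknown or untested is made for them only; others in the source may bear on it.

Compound 2 `[N-]=[N+]=NCCCCCCN[C@@H]1[C@@H](O)[C@@H](O)[C@H](O)[C@H]2COC(=O)N21` gives 116000 nM in an assay on lysate for inhibition of lysosomal alpha-mannosidase (Homo sapiens), read by reporter gene assay and fluorescence, with a stated time of 60 min (on this read-out lower numbers stand for stronger inhibition and higher numbers for weaker inhibition), the highest number of the two measured here. Its nearest neighbour is compound 1 `CCCc1cn(CCCCCCN[C@@H]2[C@@H](O)[C@@H](O)[C@H](O)[C@H]3COC(=O)N32)nn1`, which gives 17300 nM in this assay, so the step of a 6.7-fold higher number from compound 1 to compound 2 (0.83 log units; beyond the scatter) leaves compound 2 at the weak end of what has been measured.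

Compound 3 `CCCCCCCCN[C@@H]1[C@@H](O)[C@@H](O)[C@H](O)[C@H]2COC(=O)N21` differs from compound 2 in one place: ethyl in place of azido on a saturated chain carbon, six bonds along the chain from an amine nitrogen. Within the data shown here, the only measured step at this position is a 6.7-fold higher number from compound 1 to compound 2 (0.83 log units; beyond the scatter), which exchanges the same azido terminus for a 4-propyl-1H-1,2,3-triazol-1-yl group; it shows that the end of the chain matters, but an ethyl extension has no measured counterpart, so its direction cannot be read from the data with confidence. Compound 3 is therefore expected to stay near compound 2, with a step of a 1.9-fold lower number from compound 2 to compound 3 (0.29 log units; within the scatter) that is estimated to be small and toward a lower number. On that basis compound 3 is estimated at 60000 nM in this assay, within a range from 15000 nM to 240000 nM.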

Compound 3, half-maximal inhibitory concentration: 26800 nM
Beside the measured number, compound 3's estimate is 2.2-fold (0.35 log units) above it; low and high end bracket the measured number.
By their numbers in this assay, from the lowest: compounds 1 and 3 (each within the scatter of the next); then compound 2.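

Ethyl in place of azido on a saturated chain carbon, six bonds along the chain from an amine nitrogen, gives a 4.3-fold lower number from compound 2 to compound 3 (0.64 log units; beyond the scatter) in this assay, so a second replacement of the azido terminus now moves the number beyond the scatter, and the 4-propyl-1H-1,2,3-triazol-1-yl group is no longer the only such case. The two replacements cannot be told apart, as ethyl in place of 4-propyl-1H-1,2,3-triazol-1-yl gives a 1.5-fold higher number from compound 1 to compound 3 (0.19 log units; within the scatter) and so a plain alkyl end and a triazole end read alike here, while among these three compounds only the azido compound stands apart. Nothing available here accounts for the higher number of the azido compound.

The compounds shown leave open whether the chain end or the chain length governs the number, as a shorter chain such as butyl or a longer chain such as decyl would separate the two. They also leave open how an amine or a carboxylic acid at the end of the chain would read against the ethyl and triazole ends.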